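The compounds below may be only part of what the source reports. "The series", "measured", "known", "first", "only" and "open" are said of these compounds alone.

In a functional assay on SMMC-7721 cells (Homo sapiens) for cytotoxicity, read by MTT assay, with a stated time of 48 h (a lower number here means a stronger inhibitor, a higher number a weaker inhibitor), compound 1 (`COc1ccc(-c2c(-c3cc(OC)c(OC)c(OC)c3)noc2N)cc1OC`) gives > 50000 nM as a limit, not a number. Compound 2 (`COc1ccc(-c2c(-c3cc(OC)c(OC)c(OC)c3)noc2NC(C)=O)cc1`) also gives > 50000 nM as a limit, so its place is known only as that limit. Going by the values given here, the series so far offers only the limit of > 50000 nM in this assay, at which 2 of the 2 values shown sit, and no number. Compound 3 (`COc1ccc(-c2c(-c3cc(OC)c(OC)c(OC)c3)noc2NC(C)=O)cc1OC`) differs from compound 2 by methoxy in place of hydrogen on an aromatic carbon in going from 4-methoxyphenyl to 3,4-dimethoxyphenyl. No step beyond the scatter is expected in this assay and the estimated a number no higher from compound 2 to compound 3 (the limit leaves the size open) stays within it. For compound 3 the expected value is 50000 nM with an estimated range from 25000 nM to 100000 nM in this series.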

Compound 3, half-maximal inhibitory concentration: 46300 nM
Beside the measured number, compound 3's estimate is 1.1-fold (0.03 log units) above it; low and high end bracket the measured number.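

Going by these compounds alone, compound 3 gives the only true number of the series in this assay, so the 3,4-dimethoxyphenyl acetamide can be placed rather than bounded. Methoxy in place of hydrogen on an aromatic carbon gives an at least 1.0-fold lower number from compound 2 to compound 3 (0.03 log units; that floor lies within the scatter), and acetyl in place of hydrogen on the nitrogen gives an at least 1.0-fold lower number from compound 1 to compound 3 (0.03 log units; that floor lies within the scatter); the true size of both steps stays open. The other two compounds remain limits, not numbers: the limit of > 50000 nM in this assay, at which 2 of the 3 values shown sit.

As far as these compounds go, whether a hydroxy group or a longer alkoxy chain in place of this methoxy would give a step beyond the scatter stays open. So does the effect of a carboxylic acid or a longer acyl chain on the nitrogen.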